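Benzyl for ethyl on the piperazine of compound 3

A few compounds are considered here, and "the series" means these few. Any claim that something is new, unique, unknown or untested is made for them only; others in the source may bear on it.

Measured compounds:
compound 1 `Cc1ccc2oc(SCC(=O)Nc3ccc(-c4nc(-c5ccccc5)c(-c5ccccc5)n4C)cc3)nc2c1`, 22.4 ug/mL
compound 2 `Cn1c(-c2ccc(NC(=O)CSC3=NCCS3)cc2)nc(-c2ccccc2)c1-c1ccccc1`, 26.7 ug/mL
compound 3 `CCN1CCN(CC(=O)Nc2ccc(-c3nc(-c4ccccc4)c(-c4ccccc4)n3C)cc2)CC1`, 80 ug/mL

All three share the same core and differ only in the group attached to the chain carbon bound to the carbonyl. In a functional assay on MCF7 cells (Homo sapiens) for cytotoxicity, read by MTT assay, with a stated time of 24 h (on this read-out lower numbers stand for stronger inhibition and higher numbers for weaker inhibition), compound 3 gives the highest number of the three: the step of a 3.6-fold higher number from compound 1 to compound 3 (0.55 log units; beyond the scatter) and the step of a 3.0-fold higher number from compound 2 to compound 3 (0.48 log units; beyond the scatter) both lie beyond the scatter, while a 1.2-fold higher number from compound 1 to compound 2 (0.08 log units; within the scatter) does not.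

Compound 4 `Cn1c(-c2ccc(NC(=O)CN3CCN(Cc4ccccc4)CC3)cc2)nc(-c2ccccc2)c1-c1ccccc1` is the next compound, and it keeps the piperazine of compound 3. The change is phenyl in place of methyl on a saturated chain carbon bound to an amine nitrogen in a ring; cut one bond further out, it reads ethyl to benzyl. Within the data shown here, no measured step touches this position: the steps from compound 1 and compound 2 to compound 3 exchange the whole group on the chain carbon bound to the carbonyl, not a substituent on the piperazine nitrogen. They therefore say nothing direct about this step, and no step beyond the scatter is expected in this assay in either direction. Compound 4 is estimated at 60 ug/mL, within 25 ug/mL to 150 ug/mL, which corresponds to an expected step of a 1.3-fold lower number from compound 3 to compound 4 (0.12 log units; within the scatter).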

Compound 4, half-maximal inhibitory concentration: 80 ug/mL
Estimate against measurement, compound 4: 1.3-fold (0.12 log units) below, and the stated range covers the measured number.
By their numbers in this assay, from the lowest: compounds 1 and 2 (each within the scatter of the next); then compounds 3 and 4 (each within the scatter of the next).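

Phenyl in place of methyl on a saturated chain carbon bound to an amine nitrogen in a ring, which reads ethyl to benzyl when cut one bond further out, gives no change at the digits printed from compound 3 to compound 4 (within the scatter) in this assay. Among these compounds, this is the first reading at this position, since the earlier steps exchanged the whole group on the chain carbon bound to the carbonyl, and it shows that in this pair the added aromatic ring leaves the number where it was. Nothing measured here bears on why the number stays put.

From the compounds shown here alone, this rests on a single pair, so it remains open whether ethyl and benzyl are representative of this position. A carboxylic acid at the end of a longer chain, or a primary amine on the phenyl ring of the benzyl group, could still behave differently.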